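This account rests on a few compounds, and the source may have more. Where it says the series, first, only, none or still open, it means among the compounds named here.

Measured so far:
compound 1 `c1ccc(CCCCNC2CCc3ccsc3CC2)cc1` — in an assay on membranes from liver for displacement of a labelled ligand from Sigma intracellular receptor 2 (Rattus norvegicus), read by scintillation counting, with a stated time of 120 min, in the presence of a further agent that is not named here (a higher number here means a weaker inhibitor, a lower number a stronger inhibitor), compound 1 gives 5.7 nM
compound 2 `CCN(CCCCc1ccccc1)C1CCc2ccsc2CC1` — in this assay compound 2 gives 46 nM

Among the compounds with values here, compound 1 stands as the lower of the two numbers; compound 2 is separated from it by an 8.1-fold higher number from compound 1 to compound 2 (0.91 log units; beyond the scatter), the only measured step in the set, and that step concerns ethyl in place of hydrogen on the amine nitrogen.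

Compound 3 `OCc1cc2c(s1)CCC(NCCCCc1ccccc1)CC2` is not yet measured. It differs from compound 1 by hydroxymethyl in place of hydrogen on an aromatic carbon. The measured step does not bear on this change: it alters the amine nitrogen, whereas the change to compound 3 sits on the aromatic ring. Within the data shown here, no measured pair therefore informs the direction or size of the step.

Without a guide, the number for compound 3 is expected to stay close to that of compound 1, with a step of a 2.6-fold higher number from compound 1 to compound 3 (0.42 log units; beyond the scatter) expected. Compound 3 is estimated at 15 nM, within 3 nM to 80 nM.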

Compound 3, inhibition constant: 73 nM
For compound 3 the middle estimate is 4.9-fold (0.69 log units) below the measured one, and the stated range covers the measured number.
By their numbers in this assay, from the lowest: compound 1; then compounds 2 and 3 (each within the scatter of the next).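

Hydroxymethyl in place of hydrogen on the aromatic carbon next to the ring sulfur is the first measured change to the core of compound 1, and in this assay it gives a 13-fold higher number from compound 1 to compound 3 (1.11 log units; beyond the scatter), so this position does respond to substitution. The step is classed as large, whereas the change on the amine nitrogen gives an 8.1-fold higher number from compound 1 to compound 2 (0.91 log units; beyond the scatter) and is classed as modest. Compound 1 therefore keeps the lowest number, with both single changes giving higher numbers. No available evidence explains the step at this position.

The compounds shown leave open whether the step follows the hydroxyl or the added carbon, which a methyl or a methoxymethyl on the same carbon would help separate. As far as these compounds go, whether a carboxylic acid, an amine or a longer chain there gives a similar step also remains open.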